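Moving the Fluorine Around the Benzyl Ring

The source may hold more compounds than are shown below. What is called first, only, known or untested is meant among the compounds shown, and "the series" means these compounds.

Among the compounds with values here, compound 2 `Cc1cc(Nc2nc(NCc3cccc(F)c3)nc3[nH]ncc23)n[nH]1` shows the highest of the two numbers so far in an assay on isolated protein for inhibition of serine/threonine-protein kinase PAK 4 (Homo sapiens), read by HTRF, with a stated time of 60 min (on this read-out lower numbers stand for stronger inhibition and higher numbers for weaker inhibition), though its gap to compound 1 lies within the scatter: compound 2 gives 458 nM and compound 1 `Cc1cc(Nc2nc(NCc3ccccc3F)nc3[nH]ncc23)n[nH]1` gives 389 nM. Compound 3 `Cc1cc(Nc2nc(NCc3ccc(F)cc3)nc3[nH]ncc23)n[nH]1` differs from compound 2 by 4-fluorophenyl in place of 3-fluorophenyl on a saturated chain carbon bound to a nitrogen on an aromatic ring. Within the data shown here, the one comparable step also moved the fluorine on the same ring: a 1.2-fold higher number from compound 1 to compound 2 (0.07 log units; within the scatter). Moving it once more is therefore expected to give a step of about a 1.0-fold lower number from compound 2 to compound 3 (0.01 log units; within the scatter), nothing beyond the scatter. Compound 3 is estimated at 450 nM, within 200 nM to 1000 nM.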

Compound 3, half-maximal inhibitory concentration: 395 nM
Compound 3: the middle estimate sits 1.1-fold (0.06 log units) above what was measured; measured number inside the range.
By their numbers in this assay, from the lowest: compounds 1, 3 and 2 (each within the scatter of the next).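

The 4-fluorophenyl group adds two steps (a 1.2-fold lower number from compound 2 to compound 3 (0.06 log units; within the scatter)) and (a 1.0-fold higher number from compound 1 to compound 3 (0.01 log units; within the scatter)), and both lie within the scatter. With all three fluorophenyl groups now compared, moving the fluorine around this ring leaves the number unchanged within the scatter, so the three cannot be told apart here. Nothing available explains this result.
Still open, from the compounds shown here alone, is whether a different group in this place, such as an unsubstituted phenyl, a methoxyphenyl or an aminophenyl, would shift the number beyond the scatter. A longer chain between the ring and the nitrogen is also an open question.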